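The source may report more compounds than this note shows. Statements on the series, on what has been measured and on what is new or still open speak of the compounds shown alone.

The series keeps one shared core and varies the group on the sulfonyl sulfur and the substitution of the distal ring. Compound 1 `CCOc1cc(C)c(-c2cccc(COc3ccc(S(=O)(=O)CC(=O)O)cc3)c2)c(C)c1` gives 63.1 nM in a functional assay on CHO cells for agonist activity at Free fatty acid receptor 1 (Homo sapiens), read by FLIPR and calcium flux; on this read-out lower numbers stand for an effect already at smaller amounts and higher numbers for an effect only at larger amounts of compound. Compound 2 `O=C(O)CS(=O)(=O)c1ccc(OCc2cccc(-c3ccccc3)c2)cc1`, which carries a bare distal ring, gives 288 nM in this assay. Compound 3 `CCC(C(=O)O)S(=O)(=O)c1ccc(OCc2cccc(-c3c(C)cc(OC)cc3C)c2)cc1` carries a 1-carboxypropyl group on the sulfonyl sulfur; for compound 3 this assay records only a limit, > 1000 nM, so its place among the numbers shown is not a number but the boundary of the assay (the limit of > 1000 nM in this assay, at which 1 of the 3 values shown sits).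

Compound 4 `COc1cc(C)c(-c2cccc(COc3ccc(S(=O)(=O)C4(C(=O)O)CC4)cc3)c2)c(C)c1` differs from compound 3 in one place: 1-carboxycyclopropyl in place of 1-carboxypropyl on a sulfonyl sulfur. For the measured compounds named here, no step between two measured compounds mirrors this change, so no measured size can be borrowed for it. Compound 1 and compound 2, both with an unbranched carboxymethyl on the sulfonyl sulfur, sit well within the measurable window, while the branched compound 3 lies beyond it; closing the branch into a three-membered ring is a different change, and its direction is open.

Compound 4 is therefore expected to land at 600 nM, within 150 nM to 3000 nM, which would mean an estimated step of an at least 1.6-fold lower number from compound 3 to compound 4 (0.22 log units; that floor lies within the scatter).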

Compound 4, half-maximal effective concentration in the Free fatty acid receptor 1 assay: > 1000 nM
Compound 4: no number, only a limit; the forecaster's own chance of this, stated with the estimate: 35%; at least 1.6-fold (0.22 log units) between middle value and limit.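

In the Free fatty acid receptor 1 assay compound 4 gives > 1000 nM, which is a limit and not a number. In the Free fatty acid receptor 1 assay compound 3 gives > 1000 nM, which is also a limit. No step can therefore be read between compound 3 and compound 4: the limit of > 1000 nM in the Free fatty acid receptor 1 assay, at which 2 of the 4 values shown sit.

In a physicochemical assay for lipophilicity, using the shake flask method, in phosphate buffer, measured as octanol-water partition, with a stated time of 24 h, at pH 7.4, tested at 100 uM (on this read-out higher numbers stand for higher lipophilicity and lower numbers for lower lipophilicity), compound 3 gives "not determined" (no result reported). In the physicochemical assay compound 4 gives "not determined" (no result reported).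

The compounds shown leave open how 1-carboxycyclopropyl and 1-carboxypropyl on a sulfonyl sulfur compare in the Free fatty acid receptor 1 assay.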